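This account rests on a few compounds, and the source may have more. Where it says the series, first, only, none or still open, it means among the compounds named here.

Measured so far:
- compound 1, `Cc1cccnc1-c1ccc(C(=O)Nc2ccc(C(F)(F)F)cc2)cc1`: 81 nM
- compound 2, `CC(C)(C)c1ccc(NC(=O)c2ccc(-c3ncccc3F)cc2)cc1`: 1 nM

Both numbers come from a functional assay for antagonist activity at transient receptor potential cation channel subfamily V member 1 (Rattus norvegicus); a higher number here means a weaker inhibitor, a lower number a stronger inhibitor. Compound 2 has the lowest of the two numbers, and the gap to compound 1, which gives 81 nM in this assay, lies well beyond the usual scatter, so compound 2 is the stronger inhibitor of the pair.

Compound 3, `CC(C)(C)c1ccc(NC(=O)c2ccc(-c3ncccc3-c3ncc[nH]3)cc2)cc1`, has not yet been measured in this assay. It differs from compound 2 in one place: 1H-imidazol-2-yl in place of fluoro on an aromatic carbon. A single fluorine leaves and a five-membered aromatic ring with two hetero atoms, carrying one hydrogen-bond donor and one hydrogen-bond acceptor, takes its place ortho to a large group, two atoms from the ring nitrogen. For the measured compounds named here, no measured pair shows this kind of change, so nothing here tells how far the number will move. Because compound 2 already gives 1 nM, a further gain is hard to expect; the more likely outcome is a weakening, and the step expected from compound 2 to compound 3 is an 8.0-fold higher number from compound 2 to compound 3 (0.90 log units; beyond the scatter), modest but beyond the scatter. Compound 3 is therefore estimated at 8 nM, with a range from 1 nM to 80 nM.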

Compound 3, half-maximal inhibitory concentration: 694 nM
The estimate for compound 3 lay 87-fold (1.94 log units) below the measured number, outside the stated range (above it).
By their numbers in this assay, from the lowest: compound 2; then compound 1; then compound 3.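

In this assay, putting 1H-imidazol-2-yl in place of fluoro gives a 690-fold higher number from compound 2 to compound 3 (2.84 log units; beyond the scatter), a large weakening and far beyond the scatter of the assay. For the compounds shown here, this is the first direct reading at this aromatic carbon, ortho to a large group and two atoms from the ring nitrogen, and it shows that the position does not accept every group: the strong inhibition of compound 2 does not survive this single exchange. No measurement at hand shows what lies behind the loss.

The compounds shown leave open how much of the loss belongs to the five-membered aromatic ring as such and how much to the hydrogen-bond donor or acceptor that it brings, a question that a thiophene ring, with no ring nitrogen, could help to answer. They also leave open how a small group such as chlorine or methoxy would fare here, since only fluoro and 1H-imidazol-2-yl can be compared directly at this position.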